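The source may report more compounds than this note shows. Statements on the series, on what has been measured and on what is new or still open speak of the compounds shown alone.

Measured compounds:
compound 1 `Cc1cc(C)cc(CNc2cncc(-c3cc(C)cc(C)c3)c2N2CCC(N)CC2)c1` — 0.8 nM
compound 2 `Cc1nn(C)cc1C(=O)Nc1cncc(-c2cc(Cl)cc(Cl)c2)c1N1CCC(N)CC1` — 0.12 nM

In a functional assay on CHO-K1 cells for agonist activity at somatostatin receptor type 2 (Homo sapiens), read by cAMP accumulation, with a stated time of 30 min (a lower number here means that less compound is needed, a higher number that more compound is needed for the effect), compound 1 gives 0.8 nM, the higher of the two numbers; its nearest neighbour, compound 2, gives 0.12 nM, a difference that lies beyond the scatter.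

Compound 3 `Cc1cc(C)cc(-c2cncc(-c3nc4cc(C)ccc4[nH]3)c2N2CCC(N)CC2)c1` is not yet measured. It differs from compound 1 in one place: 5-methyl-1H-benzimidazol-2-yl in place of (3,5-dimethylbenzyl)amino on an aromatic carbon. Among the compounds with values here, no measured pair shows this change, so its effect is unknown. The expected step from compound 1 to compound 3, a 1.9-fold higher number from compound 1 to compound 3 (0.27 log units; within the scatter), is a modest loss, near the edge of the scatter. Compound 3 is estimated at 1.5 nM, within 0.3 nM to 8 nM.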

Compound 3, half-maximal effective concentration: 0.013 nM
Compound 3: middle estimate off by 120-fold (2.06 log units), on the high side, and the stated range ends above it.
By their numbers in this assay, from the lowest: compound 3; then compound 2; then compound 1.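

On the aromatic carbon ortho to the 4-aminopiperidin-1-yl group, the (3,5-dimethylbenzyl)amino group is not needed for high potency: in this assay, 5-methyl-1H-benzimidazol-2-yl in its place gives a large gain (a 62-fold lower number from compound 1 to compound 3 (1.79 log units; beyond the scatter)). The two groups have the same counts of heavy atoms, hydrogen-bond donors and acceptors, so those counts do not separate them. Nothing shown accounts for the gain. Going by these compounds, it remains open whether the methyl contributes, as an unsubstituted 1H-benzimidazol-2-yl would test. A 1H-imidazol-2-yl would show whether the six-membered ring of the entering group matters.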